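This account rests on a few compounds, and the source may have more. Where it says the series, first, only, none or still open, it means among the compounds named here.

In an ADME assay on MRC5 cells (Homo sapiens) for cytotoxicity, read by MTT assay (on this read-out higher numbers stand for lower toxicity in this test and lower numbers for higher toxicity in this test), compound 1 `C[Si](C)(C)C#Cc1c[nH]c(=O)[nH]c1=O` gives 124000 nM and compound 2 `CCC#Cc1c[nH]c(=O)[nH]c1=O` gives 120000 nM, so compound 2 stands level with compound 1 within the scatter. Compound 3 `CCCCCCC#Cc1c[nH]c(=O)[nH]c1=O` carries butyl in place of hydrogen on a saturated chain carbon, two bonds along the chain from a triple-bonded carbon. Among the compounds with values here, the only measured step that bears on this is a 1.0-fold lower number from compound 1 to compound 2 (0.01 log units; within the scatter), and it offers weak guidance, since it does not lengthen a chain. A modest move towards a lower number is therefore expected, an estimated 2.0-fold lower number from compound 2 to compound 3 (0.30 log units; within the scatter). Compound 3 is expected at 60000 nM, with an estimated range of 15000 nM to 150000 nM.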

Compound 3, half-maximal cytotoxic concentration: 94900 nM
Compound 3: middle estimate off by 1.6-fold (0.20 log units), on the low side; measured number inside the range.
By their numbers in this assay, from the lowest: compounds 3, 2 and 1 (each within the scatter of the next).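

In this assay the step of a 1.3-fold lower number from compound 2 to compound 3 (0.10 log units; within the scatter) shows that this position accepts butyl in place of hydrogen, read one bond further out as methyl to pentyl, with no change beyond the scatter. Unlike the earlier step, this one lengthens the chain, and the added carbon atoms leave compound 3 level with compound 2 on this read-out. Nothing available explains this outcome. From the compounds shown here alone, it remains open whether a longer chain would stay level with these compounds. Going by these compounds, an amine or a carboxylic acid at the chain end also remains untested here.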